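This account rests on a few compounds, and the source may have more. Where it says the series, first, only, none or still open, it means among the compounds named here.

Measured compounds in this series:

Compound 1 `C=CCNC(=S)NC1=C(C#N)C(c2ccc(Cl)cc2Cl)C2=C(CCCC2=O)N1c1ccc(S(N)(=O)=O)cc1` — 33%
Compound 2 `N#CC1=C(NC(=S)Nc2ccccc2)N(c2ccc(S(N)(=O)=O)cc2)C2=C(C(=O)CCC2)C1c1ccc(Cl)cc1Cl` — 55%

In a functional assay on Ehrlich cells (Mus musculus) for cytotoxicity, read by trypan blue exclusion, with a stated time of 2 h, tested at 50 ug/mL (a higher number here means a stronger effect of the compound at the concentration tested, a lower number a weaker effect), compound 1 gives 33%, and compound 2 gives 55%. Compound 2 thus stands highest of the two numbers; its nearest neighbour is compound 1, and the step of a number 22 percentage points higher from compound 1 to compound 2 (beyond the scatter) lies beyond the scatter, brought about by phenyl in place of allyl on an amide-type nitrogen.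

Compound 3 `N#CC1=C(NC(=S)Nc2ccc(Cl)cc2)N(c2ccc(S(N)(=O)=O)cc2)C2=C(C(=O)CCC2)C1c1ccc(Cl)cc1Cl` has not been measured. It differs from compound 2 by chloro in place of hydrogen on an aromatic carbon on the phenyl that was itself introduced in the step from compound 1 to compound 2, para to a large group. Among the measured compounds shown here, no measured step concerns a chloro on that ring; the only step known, a number 22 percentage points higher from compound 1 to compound 2 (beyond the scatter), exchanges the whole group on the amide-type nitrogen and so does not speak directly to this change. Without a bearing step, compound 3 is expected to show a step of a number 3 percentage points higher from compound 2 to compound 3 (within the scatter) that stays within the scatter. Compound 3 is therefore estimated to give 58%, within a range from 40% to 76%.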

Compound 3, a percentage reported as activity, at one concentration (the size of the read-out at that concentration, not a potency): 100%
Beside the measured number, compound 3's estimate is 42 percentage points below it; the whole stated range lies below it.
By their numbers in this assay, from the lowest: compound 1; then compound 2; then compound 3.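

Among the compounds shown here, the earlier compounds showed only that exchanging the whole group on the amide-type nitrogen can shift the read-out; compound 3 shows that a single chloro on an aromatic carbon of that phenyl, para to a large group, is enough to shift it further. In this assay, this one-atom change gives a number 45 percentage points higher from compound 2 to compound 3 (beyond the scatter), a large step set against the modest one that phenyl brought in place of allyl. Read as a whole, 4-chlorophenyl in place of allyl on the amide-type nitrogen gives a number 67 percentage points higher from compound 1 to compound 3 (beyond the scatter), and no evidence is at hand that would explain why the chloro has so large an effect.

The compounds shown leave open whether this gain belongs to chloro itself or would also come with another group at the same place, such as fluoro, methyl or methoxy, and whether it depends on the 2,4-dichlorophenyl and sulfonamide parts that all three compounds share. Since the read-out comes from one concentration, they show a stronger effect of compound 3 than of compound 2 at that concentration only and leave open how the two compare at any other.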